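Benzyl Substituent Swaps in One Antiproliferative Series

The compounds below may be only part of what the source reports. "The series", "measured", "known", "first", "only" and "open" are said of these compounds alone.

Measured so far, in a functional assay on MIA PaCa-2 cells (Homo sapiens) for antiproliferative activity, read by sulforhodamine B assay, with a stated time of 48 h; on this read-out lower numbers stand for stronger inhibition of growth and higher numbers for weaker inhibition of growth:
- compound 1 `O=C(NCc1cn(Cc2ccc(F)cc2)nn1)c1cn(-c2ccccc2)nc1-c1ccccc1` gives 9600 nM
- compound 2 `O=C(NCc1cn(Cc2ccc(Cl)cc2)nn1)c1cn(-c2ccccc2)nc1-c1ccccc1` gives 8700 nM
- compound 3 `COc1ccc(Cn2cc(CNC(=O)c3cn(-c4ccccc4)nc3-c3ccccc3)nn2)cc1` gives 10200 nM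

Compound 3 has the highest of the three numbers, but its gaps to the others are small: a 1.1-fold higher number from compound 1 to compound 3 (0.03 log units; within the scatter) and a 1.2-fold higher number from compound 2 to compound 3 (0.07 log units; within the scatter), both within the scatter. The step of a 1.1-fold lower number from compound 1 to compound 2 (0.04 log units; within the scatter) is likewise within the scatter. Across these three compounds, swapping the substituent on the benzyl ring has therefore made no difference that can be told apart from noise.

Compound 4 `COc1cc(Cn2cc(CNC(=O)c3cn(-c4ccccc4)nc3-c3ccccc3)nn2)cc(OC)c1` continues this pattern with a further change at the same place: 3,5-dimethoxyphenyl in place of 4-methoxyphenyl on a saturated chain carbon bound to an aromatic nitrogen. Every step measured so far at this position stayed within the scatter, so no step beyond the scatter is expected here either, in either direction.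

Compound 4 is thus estimated at 10000 nM in this assay, within a range of 5000 nM to 20000 nM, an expected step of a 1.0-fold lower number from compound 3 to compound 4 (0.01 log units; within the scatter).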

Compound 4, concentration for 50% growth inhibition: 190 nM
Compound 4: middle estimate off by 53-fold (1.72 log units), on the high side; the measured number lies below the stated range.
By their numbers in this assay, from the lowest: compound 4; then compounds 2, 1 and 3 (each within the scatter of the next).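

In this assay the move to 3,5-dimethoxybenzyl brings a 54-fold lower number from compound 3 to compound 4 (1.73 log units; beyond the scatter) and likewise a 46-fold lower number from compound 2 to compound 4 (1.66 log units; beyond the scatter) and a 51-fold lower number from compound 1 to compound 4 (1.70 log units; beyond the scatter) as well, so this position can strongly change growth inhibition after all. The fluoro, chloro and methoxy compounds stay within the scatter of one another, which means that only the 3,5-dimethoxybenzyl group has revealed this sensitivity so far. Nothing measured here accounts for the gain.

The change both adds a methoxy group and alters where the methoxy groups sit on the ring, and the compounds shown cannot separate these two parts. Also open, from the compounds shown here alone, is how an ethoxy group, an amine or a carboxylic acid would fare in place of the methoxy groups of compound 4.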